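Swapping methyl for chloro on a phenoxy ring

The source may report more compounds than this note shows. Statements on the series, on what has been measured and on what is new or still open speak of the compounds shown alone.

Measured so far:
compound 1, `Cc1nn(Cc2cccc(C(=O)Nc3ccccc3)c2)c(C)c1NC(=O)c1ccc(COc2ccccc2)cc1`, 6400 nM
compound 2, `CNC(=O)c1cccc(Cn2nc(C)c(NC(=O)c3ccc(COc4cccc(C)c4)cc3)c2C)c1`, 6200 nM

Both values come from a functional assay on MIA PaCa-2 cells (Homo sapiens) for antiproliferative activity, read by MTT assay, with a stated time of 72 h; on this read-out lower numbers stand for an effect already at smaller amounts and higher numbers for an effect only at larger amounts of compound. Compound 2 gives 6200 nM, and the value of compound 1 sits within the usual scatter of that figure, so the two cannot be told apart. Compound 3, `CNC(=O)c1cccc(Cn2nc(C)c(NC(=O)c3ccc(COc4cccc(Cl)c4)cc3)c2C)c1`, has not been measured yet. It differs from compound 2 by chloro in place of methyl on an aromatic carbon. Going by the values given here, no measured pair shows this change, so its size is unknown here; the expectation is a step of a 1.0-fold lower number from compound 2 to compound 3 (0.01 log units; within the scatter), not beyond the scatter. Compound 3 is estimated at 6000 nM, between 3000 nM and 12000 nM.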

Compound 3, half-maximal effective concentration: 5900 nM
For compound 3 the middle estimate is 1.0-fold (0.01 log units) above the measured one; the measured number falls inside the stated range.
By their numbers in this assay, from the lowest: compounds 3, 2 and 1 (each within the scatter of the next).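

Chloro in place of methyl on this phenoxy ring gives a 1.1-fold lower number from compound 2 to compound 3 (0.02 log units; within the scatter) in this assay, so the two cannot be told apart. Going by these compounds alone, this is the first measured pair for this change, and in this single pair, 3-methylphenoxy and 3-chlorophenoxy give no readable difference. Nothing available explains why the two read alike. Still open, going by these compounds, is whether an amine or a carboxylic acid at this place would give a clearly different number. Also open, on these data alone, is whether the same swap would read alike with other groups elsewhere on the molecule.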